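This account rests on a few compounds, and the source may have more. Where it says the series, first, only, none or still open, it means among the compounds named here.

Of the compounds shown here, three sharing one core have been measured in a functional assay on A549 cells (Homo sapiens) for inhibition, read by sulforhodamine B assay, with a stated time of 48 h; on this read-out higher numbers stand for weaker inhibition of growth and lower numbers for stronger inhibition of growth. Compound 1 (`COc1ccc(/C=C/C(=O)C(=Cc2cccc(F)c2)C(=O)/C=C/c2ccc(OC)c(OC)c2)cc1OC`) gives 580 nM, compound 2 (`COc1ccc(OC)c(C=C(C(=O)/C=C/c2ccc(O)c(OC)c2)C(=O)/C=C/c2ccc(O)c(OC)c2)c1`) gives 670 nM and compound 3 (`COc1ccc(OC)c(C=C(C(=O)/C=C/c2ccc(OC)c(OC)c2)C(=O)/C=C/c2ccc(OC)c(OC)c2)c1`) gives 530 nM. Compound 2 thus stands within the scatter of both of the others, and these numbers set no order among the three.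

The next compound to be tested is compound 4 (`CCc1ccc(C=C(C(=O)/C=C/c2ccc(O)c(OC)c2)C(=O)/C=C/c2ccc(O)c(OC)c2)cc1`), which differs from compound 2 in one place, on a double-bonded chain carbon bound to a double-bonded chain carbon. There, 4-ethylphenyl takes the place of 2,5-dimethoxyphenyl: 4-ethylphenyl in place of 2,5-dimethoxyphenyl on a double-bonded chain carbon bound to a double-bonded chain carbon.

For the measured compounds named here, the only measured step at this place, a 1.1-fold lower number from compound 1 to compound 3 (0.04 log units; within the scatter), puts 2,5-dimethoxyphenyl in place of 3-fluorophenyl, and on that small step no shift beyond the scatter is expected in this assay for the new exchange. The guide is a thin one. Going by the values given here, no measured compound carries 4-ethylphenyl, and that step was taken with other groups elsewhere on the core than those of compound 2. The range is therefore kept wide.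

The expected change is a 1.1-fold lower number from compound 2 to compound 4 (0.05 log units; within the scatter). For compound 4 the estimated value is 600 nM, with an expected range from 250 nM to 1400 nM.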

Compound 4, concentration for 50% growth inhibition: 550 nM
The estimate for compound 4 lay 1.1-fold (0.04 log units) above the measured number, within the range that was stated.
By their numbers in this assay, from the lowest: compounds 3, 4, 1 and 2 (each within the scatter of the next).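

In this assay, for the compounds shown here, 4-ethylphenyl in place of 2,5-dimethoxyphenyl gives a 1.2-fold lower number from compound 2 to compound 4 (0.09 log units; within the scatter) on the core that carries the side arms of compound 2, whereas the only earlier step at this place was taken with other groups elsewhere on the core. The exchange removes the oxygen atoms from the group on the double-bonded chain carbon, leaving a ring with an ethyl chain and carbon only, and the number still does not move beyond the scatter, so in this pair those oxygen atoms are not needed to hold the value in this assay. Nothing on hand gives a reason for this flat result.

The compounds shown leave open whether 4-ethylphenyl would behave the same way on the core of compound 3, whose side arms differ from those of compound 2. They also leave open whether this place stays as flat with a group of another kind, such as an aminomethylphenyl, a carboxylic acid on the ring, or a longer chain such as 4-butylphenyl, since every group seen here is a phenyl ring with small substituents.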